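Nitrogen substituents: from compound 3 to compound 4

The source may report more compounds than this note shows. Statements on the series, on what has been measured and on what is new or still open speak of the compounds shown alone.

Values in a functional assay on LNCaP cells (Homo sapiens) for inhibition, read by WST assay, with a stated time of 48 h; on this read-out lower numbers stand for stronger inhibition of growth and higher numbers for weaker inhibition of growth:
- compound 1 `C=C(C)C(=O)N(C)C(=O)/C=C/c1cc(OC)c(OC)c(OC)c1`: > 10000 nM (a limit)
- compound 2 `C#CCN(C(=O)/C=C/c1cc(OC)c(OC)c(OC)c1)C(=O)C(=C)C`: > 10000 nM (a limit)
- compound 3 `C=C(C)C(=O)NC(=O)/C=C/c1cc(OC)c(OC)c(OC)c1`: 10000 nM

Within the data shown here, compound 3 gives the only actual number so far. Compound 1 and compound 2 stand at the limit of > 10000 nM in this assay, at which 2 of the 3 values shown sit.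

Compound 4 `C=C(C)C(=O)N(Cc1ccc(Br)cc1)C(=O)/C=C/c1cc(OC)c(OC)c(OC)c1` differs from compound 3 as follows: 4-bromobenzyl in place of hydrogen on an amide-type nitrogen.

The measured changes on this nitrogen are a number no higher from compound 1 to compound 3 (the limit leaves the size open), a number no higher from compound 2 to compound 3 (the limit leaves the size open) and a step that the two limits leave unreadable from compound 1 to compound 2. None has a readable size, and none involves an aromatic ring, so they offer only weak guidance. The expected step in this assay is no change at the digits printed from compound 3 to compound 4 (within the scatter), with nothing beyond the scatter foreseen. For compound 4 the estimate is 10000 nM, with an expected range of 3000 nM to 30000 nM.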

Compound 4, concentration for 50% growth inhibition: 7700 nM
For compound 4 the middle estimate is 1.3-fold (0.11 log units) above the measured one; the range from low to high includes it.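

In this assay the first aromatic ring on the amide-type nitrogen gives a 1.3-fold lower number from compound 3 to compound 4 (0.11 log units; within the scatter) and so leaves 4-bromobenzyl and hydrogen indistinguishable here. Floors alone can be read for an at least 1.2-fold lower number from compound 1 to compound 4 (0.11 log units; that floor lies within the scatter) and for an at least 1.2-fold lower number from compound 2 to compound 4 (0.11 log units; that floor lies within the scatter) as the two other substituted compounds are limits and not numbers: the limit of > 10000 nM in this assay, at which 2 of the 4 values shown sit.

Still open, going by these compounds, are the true sizes of those two steps. Also open, on these data alone, is whether an amine or a carboxylic acid on the benzyl ring, or a longer chain on this nitrogen, would move the number beyond the scatter.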